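Swapping Acetamidomethyl for Piperazinyl on the Sulfonamide Ring

A few compounds are considered here, and "the series" means these few. Any claim that something is new, unique, unknown or untested is made for them only; others in the source may bear on it.

Among the measured compounds shown here, compound 2 `CC(=O)NCc1ccc(S(=O)(=O)Nc2ccc(Oc3ccc(Cl)c(C(F)(F)F)c3)c(C#N)c2)cc1` stands highest of the two numbers so far: in an assay for inhibition of platelet-activating factor acetylhydrolase (Rattus norvegicus), in plasma, with stated times of 30 min and 10 min, tested at 250 nM (a higher number here means more inhibition at the concentration tested (going by the name of the read-out), a lower number less inhibition), compound 2 gives 80%. For the measured compounds named here, its nearest neighbour, compound 1 `N#Cc1cc(NS(=O)(=O)c2ccc(NC(=O)N3CCOCC3)cc2)ccc1Oc1ccc(Cl)c(C(F)(F)F)c1`, gives 64% in this assay, and the only measured step, a number 16 percentage points higher from compound 1 to compound 2 (beyond the scatter), shows that trading one group for another at the same place can move the reading beyond the scatter. Compound 3 `N#Cc1cc(NS(=O)(=O)c2ccc(N3CCNCC3)cc2)ccc1Oc1ccc(Cl)c(C(F)(F)F)c1` differs from compound 2 by piperazin-1-yl in place of acetamidomethyl on an aromatic carbon. Going by the values given here, no measured step covers this exchange, so its direction is unknown. The estimate is that compound 3 gives 70% in this assay, expected between 45% and 90%, a step of a number 10 percentage points lower from compound 2 to compound 3 (within the scatter) that is expected to stay within the scatter.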

Compound 3, a percentage reported as inhibition, at one concentration (the size of the read-out at that concentration, not a potency): 68%
Estimate against measurement, compound 3: 2 percentage points above; the range from low to high includes it.
By their numbers in this assay, from the lowest: compounds 1 and 3 (each within the scatter of the next); then compound 2.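

In this assay, piperazin-1-yl in place of acetamidomethyl gives a number 12 percentage points lower from compound 2 to compound 3 (beyond the scatter), so the two groups are not interchangeable on this aromatic carbon. Piperazin-1-yl in place of ((morpholin-4-yl)carbonyl)amino gives a number 4 percentage points higher from compound 1 to compound 3 (within the scatter), so these two groups cannot be told apart here, and acetamidomethyl alone stands clear of both others, by modest steps. Nothing available gives a reason for these differences. Still open, from the compounds shown here alone, is how a carboxylic acid or a simple primary amine on this carbon would compare, and whether a longer chain carrying the acetamide would read higher than compound 2.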